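Removing a Chloro Group from a Weakly Cytotoxic Scaffold

The source may report more compounds than this note shows. Statements on the series, on what has been measured and on what is new or still open speak of the compounds shown alone.

Compound 1 `Nc1cc(-c2cnc3[nH]cc(-c4ccncc4)c3c2)ccc1Cl` and compound 2 `Nc1cc(NS(=O)(=O)c2ccc(F)cc2F)cc(-c2cnc3[nH]cc(-c4ccncc4)c3c2)c1` share a core and were both tested in a functional assay on MCF7 cells (Homo sapiens) for cytotoxicity, read by MTT assay, with a stated time of 48 h; on this read-out lower numbers stand for stronger inhibition and higher numbers for weaker inhibition. Compound 1 gives 12000 nM, the highest of the two numbers, and compound 2 gives 6600 nM; the gap between them lies within the usual scatter, so neither can be called the stronger. Compound 3 `Nc1cccc(-c2cnc3[nH]cc(-c4ccncc4)c3c2)c1` has not yet been measured. It differs from compound 1 by hydrogen in place of chloro on an aromatic carbon. Among the compounds with values here, no measured pair here shows the effect of such a change, so the expectation rests on compound 1 alone. The group that leaves is a single heavy atom, and both measured compounds sit in the same weak range. The expected step in this assay is a 1.3-fold higher number from compound 1 to compound 3 (0.10 log units; within the scatter), with no clear direction beyond the scatter. Compound 3 is therefore estimated at 15000 nM in this assay, within a range from 5000 nM to 45000 nM.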

Compound 3, half-maximal inhibitory concentration: 2300 nM
Beside the measured number, compound 3's estimate is 6.5-fold (0.81 log units) above it, and the stated range ends above it.
By their numbers in this assay, from the lowest: compound 3; then compounds 2 and 1 (each within the scatter of the next).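

In this assay this position does respond to what sits on it: the step is a 5.2-fold lower number from compound 1 to compound 3 (0.72 log units; beyond the scatter), and it lies beyond the scatter. The earlier compounds shown here offered no step of any kind, whereas this pair differs in one place only, so the change in the number can be tied to that place. Here a single chlorine, ortho to the amino group and para to the large group, separates the two compounds, and the one carrying hydrogen has the lower number; nothing measured alongside this step explains how the change acts.

Only chloro and hydrogen are shown at this place, so the outcome with a fluoro, methyl or methoxy group there remains open. Going by these compounds, whether the same step would appear in another cell line also remains open.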